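The source may report more compounds than this note shows. Statements on the series, on what has been measured and on what is new or still open speak of the compounds shown alone.

Measured compounds:
- compound 1, `Cc1noc(NS(=O)(=O)c2ccc(NC(=O)c3cc4ccccc4oc3=O)cc2)c1C`, 19900 nM in a functional assay on PANC-1 cells (Homo sapiens) for antiproliferative activity, read by fluorescence and resazurin assay, with a stated time of 48 h; on this read-out lower numbers stand for stronger inhibition and higher numbers for weaker inhibition
- compound 2, `O=C(N/N=C/c1ccncc1)c1cc2cc([N+](=O)[O-])ccc2oc1=O`, 26100 nM in this assay
- compound 3, `Cc1noc(NS(=O)(=O)c2ccc(NC(=O)c3cc4cc([N+](=O)[O-])ccc4oc3=O)cc2)c1C`, 11900 nM in this assay

Compounds 1 and 3 share one core and differ in a single place: hydrogen in place of nitro on an aromatic carbon. The effect of that change on growth inhibition is known, since going from compound 3 to compound 1 gives a 1.7-fold higher number from compound 3 to compound 1 (0.22 log units; within the scatter), a shift that the usual scatter of such measurements can account for on its own.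

Compound 2 carries the nitro on a different core; how its core differs from that of compound 3 is not broken down here. Compound 2 gives a number that stands close to compound 1 and somewhat apart from compound 3.

The unmeasured compound 4, `O=C(N/N=C/c1ccncc1)c1cc2ccccc2oc1=O`, is related to compound 2 by the same change: hydrogen in place of nitro on an aromatic carbon. The place is described in the same words in both cases, so the same change is made twice, once on each core. Going by the values given here, only the pair compound 3 to compound 1 gives a measured step for it.

On that basis the step from compound 2 to compound 4 is expected to be a 1.5-fold higher number from compound 2 to compound 4 (0.16 log units; within the scatter), resting on the step from compound 3 to compound 1 a 1.7-fold higher number from compound 3 to compound 1 (0.22 log units; within the scatter), with added uncertainty because the core is different. Compound 4 is therefore expected to give 38000 nM in this assay, estimated to lie between 15000 nM and 100000 nM.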

Compound 4, half-maximal inhibitory concentration: 9750 nM
Compound 4: the middle estimate sits 3.9-fold (0.59 log units) above what was measured; the measured number lies below the stated range.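

Replacing the nitro group with hydrogen on the core of compound 2 gives a 2.7-fold lower number from compound 2 to compound 4 (0.43 log units; beyond the scatter) in this assay, so here the compound without the nitro group gives the lower number. Set beside the same change on the core of compound 3, the two results do not agree: the same change on two cores in this assay, a 1.7-fold higher number (0.22 log units; within the scatter) from compound 3 to compound 1 and a 2.7-fold lower number (0.43 log units; beyond the scatter) from compound 2 to compound 4, 4.5-fold (0.65 log units) apart, beyond the scatter of two such steps

This shows that, in this small series, the step measured on one core could not be carried over to the other, so the change has to be measured on each core rather than assumed. Going by these compounds alone, it does not show why the two cores differ, and with only one pair on each core it gives no rule for any other core.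

The compounds shown leave open whether another group at the same place, such as an amine, a methoxy group or a chlorine atom, would give steps that also differ from one core to the other. They also leave open how the exchange of nitro for hydrogen would behave on a third core, for instance one carrying a carboxylic acid or a longer chain.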